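Compound 4: (oxolan-3-yl)methyl in place of cyclobutyl

The source may hold more compounds than are shown below. What is called first, only, known or untested is meant among the compounds shown, and "the series" means these compounds.

In a toxicity assay on HT-29 cells (Homo sapiens) for cytotoxicity (a lower number here means that less compound is tolerated, a higher number that more compound is tolerated), compound 3 (`CN1C(=S)[C@@H](NC(=O)c2nc(Cc3ccccc3)n(C3CCC3)n2)COc2ccccc21`) reads > 100000 nM, which is a limit of the assay and not a number. Compound 1 (`CCCCCn1nc(C(=O)N[C@H]2COc3ccccc3N(C)C2=S)nc1Cc1ccccc1`) reads > 100000 nM, also a limit. Compound 2 (`CN1C(=S)[C@@H](NC(=O)c2nc(Cc3ccccc3)n(CCCCC#N)n2)COc2ccccc21`) reads > 100000 nM, again a limit. The record so far is therefore (the limit of > 100000 nM in this assay, at which 3 of the 3 values shown sit).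

Compound 4 (`CN1C(=S)[C@@H](NC(=O)c2nc(Cc3ccccc3)n(CC3CCOC3)n2)COc2ccccc21`) shares its core with compound 3 and differs in one place, on an aromatic nitrogen, where (oxolan-3-yl)methyl stands in place of cyclobutyl: (oxolan-3-yl)methyl in place of cyclobutyl on an aromatic nitrogen.

Among the compounds with values here, three measured steps bear on this change. Putting cyclobutyl in place of pentyl on that nitrogen gives a step that the two limits leave unreadable from compound 1 to compound 3. Putting cyclobutyl in place of 4-cyanobutyl gives a step that the two limits leave unreadable from compound 2 to compound 3. Cyano in place of methyl on the chain gives a step that the two limits leave unreadable from compound 1 to compound 2. None of the three has a size that can be carried over to the new group, and none points in a direction. Pentyl, 4-cyanobutyl and cyclobutyl all end at the same limit, so no step beyond the scatter is expected in this assay, and another limit is the likeliest report.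

The estimated step is a number no higher from compound 3 to compound 4 (the limit leaves the size open).

Compound 4 is expected at 100000 nM, within an estimated range of 40000 nM to 200000 nM.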

Compound 4, half-maximal cytotoxic concentration: > 100000 nM
Compound 4: a limit, no number; the forecaster's own chance of this, stated with the estimate: 85%; the middle value sits exactly at the limit.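

In this assay compound 4 reads > 100000 nM, which is a limit and not a number. Its steps from compound 1, compound 2 and compound 3 therefore cannot be read. The record stays at a single value: the limit of > 100000 nM in this assay, at which 4 of the 4 values shown sit.

The compounds shown leave open whether the group on the aromatic nitrogen makes any difference to cytotoxicity.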